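Cytotoxicity at the Limit Carried From Compound 2 to Compound 3

The source may report more compounds than this note shows. Statements on the series, on what has been measured and on what is new or still open speak of the compounds shown alone.

Compound 1 `CC(C)[C@H](N)C(=O)OC1CCN(S(=O)(=O)c2cc(C(=O)Nc3cc(F)c(F)c(F)c3)ccc2F)CC1` and compound 2 `NCC(=O)OC1CCN(S(=O)(=O)c2cc(C(=O)Nc3cc(F)c(F)c(F)c3)ccc2F)CC1` share one core and differ only at the saturated chain carbon bound to an amine nitrogen and a carbonyl carbon, where compound 2 carries hydrogen in place of isopropyl. In an ADME assay on HepG2 2.2.15 cells (Homo sapiens) for cytotoxicity (on this read-out higher numbers stand for lower toxicity in this test and lower numbers for higher toxicity in this test), compound 1 gives no number but a limit of the assay, > 10000 nM. In this assay compound 2 likewise gives only a limit, > 10000 nM. The step that the two limits leave unreadable from compound 1 to compound 2 is therefore of unknown size, since the limit of > 10000 nM in this assay, at which 2 of the 2 values shown sit, holds both ends of it. Compound 2 thus stands at the limit, without a value of its own on this read-out.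

Compound 3 `C[C@H](N)C(=O)OC1CCN(S(=O)(=O)c2cc(C(=O)Nc3cc(F)c(F)c(F)c3)ccc2F)CC1` differs from compound 2 in one place: methyl in place of hydrogen on a saturated chain carbon bound to an amine nitrogen and a carbonyl carbon. Going by the values given here, the only measured step that bears on this change is the one from compound 1 to compound 2, and it cannot be read in size because the limit of > 10000 nM in this assay, at which 2 of the 2 values shown sit, holds both of its values. With nothing to suggest a move beyond the scatter, compound 3 is expected to stay at the limit, an expected step that the limit leaves unreadable from compound 2 to compound 3 in this assay. The estimate for compound 3 is 20000 nM, with a range from 10000 nM to 50000 nM.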

Compound 3, half-maximal cytotoxic concentration: 4810 nM
Beside the measured number, compound 3's estimate is 4.2-fold (0.62 log units) above it, and the stated range ends above it.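

With compound 3, the saturated chain carbon bound to an amine nitrogen and a carbonyl carbon gives its first readable change in this assay: methyl in place of hydrogen brings an at least 2.0-fold lower number from compound 2 to compound 3 (0.31 log units; beyond the scatter) and, on this read-out, the lower number stands for higher toxicity in this test. Methyl in place of isopropyl at the same place brings an at least 2.0-fold lower number from compound 1 to compound 3 (0.31 log units; beyond the scatter) and shows that compound 3 lies under the limits of both neighbours, whichever of them serves as the comparison. The read-out therefore does not run in one direction from hydrogen through methyl to isopropyl, as the methyl compound alone gives a number while the groups on either side of it stay at the limit.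

On these data alone, the step from compound 1 to compound 2 still cannot be read, and the true size of both new steps stays open, since one end of each rests on a limit: the limit of > 10000 nM in this assay, at which 2 of the 3 values shown sit. As far as these compounds go, whether an ethyl group, a longer chain or a hydroxymethyl group on this carbon would also bring the number down remains open.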